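The source may hold more compounds than are shown below. What is called first, only, known or untested is meant among the compounds shown, and "the series" means these compounds.

Series notes. For the measured compounds named here, compound 3 `Cc1cc(-c2ccc(Cl)cc2)c(S(C)(=O)=O)cc1C(=O)N=C(N)N` gives the highest of the three numbers so far: in a functional assay for inhibition of sodium/hydrogen exchanger (Oryctolagus cuniculus) (on this read-out higher numbers stand for weaker inhibition and lower numbers for stronger inhibition), compound 3 gives 45 nM. Compound 1 `Cc1cc(F)c(S(C)(=O)=O)cc1C(=O)N=C(N)N` sits within the scatter of it, since compound 1 gives 44 nM, while compound 2 `CCc1cc(C)c(C(=O)N=C(N)N)cc1S(C)(=O)=O` gives 4.8 nM. Next change: ethylsulfanyl in place of 4-chlorophenyl on an aromatic carbon, giving compound 4 `CCSc1cc(C)c(C(=O)N=C(N)N)cc1S(C)(=O)=O`. The bearing steps are a 9.4-fold higher number from compound 2 to compound 3 (0.97 log units; beyond the scatter) and a 9.2-fold lower number from compound 1 to compound 2 (0.96 log units; beyond the scatter), whereas a 1.0-fold higher number from compound 1 to compound 3 (0.01 log units; within the scatter). Ethylsulfanyl, at three heavy atoms, resembles the ethyl of compound 2 more than the 4-chlorophenyl it replaces, so in this assay the number is expected to move back toward that of compound 2, which gives 4.8 nM. The expected step is therefore a 5.6-fold lower number from compound 3 to compound 4 (0.75 log units; beyond the scatter). For compound 4 the estimate is 8 nM, within 3 nM to 25 nM.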

Compound 4, half-maximal inhibitory concentration: 5.9 nM
Estimate against measurement, compound 4: 1.4-fold (0.13 log units) above; measured number inside the range.
By their numbers in this assay, from the lowest: compounds 2 and 4 (each within the scatter of the next); then compounds 1 and 3 (each within the scatter of the next).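

At this position ethylsulfanyl and ethyl cannot be told apart in this assay, with a 1.2-fold higher number from compound 2 to compound 4 (0.09 log units; within the scatter), so the low number no longer rests on ethyl alone. Ethylsulfanyl stands clear of 4-chlorophenyl, with a 7.6-fold lower number from compound 3 to compound 4 (0.88 log units; beyond the scatter), and of fluoro, with a 7.5-fold lower number from compound 1 to compound 4 (0.87 log units; beyond the scatter). No evidence at hand accounts for these steps. Open, as far as these compounds go, is whether a longer chain such as butylsulfanyl keeps the number as low as ethylsulfanyl does. Also open, from the compounds shown here alone, is how an amine or a carboxylic acid at this position would compare.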